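This account rests on a few compounds, and the source may have more. Where it says the series, first, only, none or still open, it means among the compounds named here.

Measured so far:
- compound 1, `O=C(NCc1ccc(S(=O)(=O)N2CCCCC2)cc1)c1ccn2cncc2c1`: 1700 nM
- compound 2, `O=C(NCc1ccc(S(=O)(=O)c2ccccc2)cc1)c1cnc2nccn2c1`: 2 nM

In an assay for inhibition of Nicotinamide phosphoribosyltransferase (Homo sapiens), read by mass spectrometry, with stated times of 15 min and 30 min (a lower number here means a stronger inhibitor, a higher number a weaker inhibitor), compound 1 gives 1700 nM, the higher of the two numbers. Among the measured compounds shown here, the only comparison is compound 2, which in this assay gives 2 nM, a far lower number, well beyond the scatter; the two compounds differ in more than one place, so the pair shows only that the series spans a wide range, not which part of the structure carries it.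

Compound 3, `O=C(NCc1ccc(S(=O)(=O)N2CCCCC2)cc1)c1cc2cccnc2s1`, is not yet measured. It differs from compound 1 in one place: a group of 9 heavy atoms (7 carbon, 1 nitrogen, 1 sulfur; one five-membered aromatic ring with 1 hetero atom, one six-membered aromatic ring with 1 hetero atom) in place of a group of 9 heavy atoms (7 carbon, 2 nitrogen; one five-membered aromatic ring with 2 hetero atoms, one six-membered aromatic ring with 1 hetero atom), on a carbonyl carbon. The count of hydrogen-bond acceptors is unchanged and the replacement sits on the same carbonyl carbon of the amide.

For the measured compounds named here, no step between measured compounds is known for such a change, and nothing in the data shows how the bicyclic group on the carbonyl carbon sets the number. The expectation is therefore a modest step from compound 1 to compound 3, a 1.7-fold lower number from compound 1 to compound 3 (0.23 log units; within the scatter), possibly toward a lower number but likely within the scatter. For compound 3 in this assay the estimate is 1000 nM, with a range from 200 nM to 5000 nM.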

Compound 3, half-maximal inhibitory concentration: 8 nM
Beside the measured number, compound 3's estimate is 130-fold (2.10 log units) above it; measured number outside the range, below it.
By their numbers in this assay, from the lowest: compound 2; then compound 3; then compound 1.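

In this assay, the group on the carbonyl carbon emerges as a strong control on the number: replacing the group with 7 carbon and 2 nitrogen atoms by the one with 7 carbon, 1 nitrogen and 1 sulfur atom gives a 210-fold lower number from compound 1 to compound 3 (2.33 log units; beyond the scatter), with the rest of the structure held constant. The two groups have the same heavy-atom count, hydrogen-bond donor and acceptor counts and net charge, and both contain one five-membered and one six-membered aromatic ring, so these shared counts cannot account for the difference at this place. No measurement at hand bears on why the step is so large, and its origin remains unassigned.

From the compounds shown here alone, this is a single step on a single background, so it remains open whether the sulfur-containing group would have a similar effect with the phenyl group on the sulfonyl, and which feature of the exchanged groups carries the step. Also open, going by these compounds, is how far the number depends on a fused bicyclic group at all, which smaller groups on the carbonyl carbon, such as a methyl group or an amine, could test.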